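The compounds below may be only part of what the source reports. "The series", "measured", "known", "first", "only" and "open" are said of these compounds alone.

Compound 1 `N#CNC(=N)NCCCCCn1nc(-c2ccccc2)ccc1=O`: in a functional assay on the whole organism (stomach) with Rattus norvegicus as the target (on this read-out lower numbers stand for an effect already at smaller amounts and higher numbers for an effect only at larger amounts of compound), compound 1 gives > 100 mg/kg, which is a limit of the assay and not a number.
Compound 2 `C/N=C(\S)NCCCCCn1nc(-c2ccccc2)ccc1=O`: in this assay compound 2 gives 35.3 mg/kg.
Compound 3 `C/N=C(\S)NCCCn1nc(-c2ccccc2)ccc1=O`: in this assay compound 3 gives > 100 mg/kg, again only a limit of the assay.

Compound 2 and compound 1 share their core and differ only where (a group of 5 heavy atoms (2 carbon, 3 nitrogen; no ring) in place of a group of 4 heavy atoms (2 carbon, 1 nitrogen, 1 sulfur; no ring), on an amine nitrogen). That exchange gave an at least 2.8-fold higher number from compound 2 to compound 1 (0.45 log units; beyond the scatter), and the reading for compound 1 sits at the limit of > 100 mg/kg in this assay, at which 2 of the 3 values shown sit, so the full size of the step stays hidden. Compound 3 differs from compound 2 in the core itself, where (a group of 5 heavy atoms (2 carbon, 2 nitrogen, 1 sulfur; no ring) in place of a group of 7 heavy atoms (4 carbon, 2 nitrogen, 1 sulfur; no ring), on a saturated chain carbon, three bonds along the chain from an aromatic nitrogen); this gave an at least 2.8-fold higher number from compound 2 to compound 3 (0.45 log units; beyond the scatter). Compound 4 `N#CNC(=N)NCCCn1nc(-c2ccccc2)ccc1=O` has not yet been measured. It carries the core of compound 3 and differs from compound 3 where (a group of 5 heavy atoms (2 carbon, 3 nitrogen; no ring) in place of a group of 4 heavy atoms (2 carbon, 1 nitrogen, 1 sulfur; no ring), on an amine nitrogen); the place is the same as in the change from compound 2 to compound 1, so it is the same change. Since that change gave an at least 2.8-fold higher number from compound 2 to compound 1 (0.45 log units; beyond the scatter) and compound 3 already sits at the limit of > 100 mg/kg in this assay, at which 2 of the 3 values shown sit, compound 4 is expected to show a step that the limit leaves unreadable from compound 3 to compound 4, most probably again reported only as a limit. The estimate for compound 4 is 300 mg/kg, between 100 mg/kg and 1000 mg/kg.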

Compound 4, dose for half-maximal effect: > 100 mg/kg
Compound 4 gave a limit, no number; the forecaster's own chance of this, stated with the estimate: 90%; the middle value lies beyond the limit too.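

In this assay compound 4 gives > 100 mg/kg, which is a limit of the assay and not a number. Among these compounds, compound 3 also stands at a limit, so the steps between two limits cannot be read, and it remains unknown whether the exchange on the amine nitrogen acts on the core of compound 3 as it did on the core of compound 2, since the readings collect at one ceiling: the limit of > 100 mg/kg in this assay, at which 3 of the 4 values shown sit. The one readable step is an at least 2.8-fold higher number from compound 2 to compound 4 (0.45 log units; beyond the scatter), which shows that compound 4 does not reach the reading of compound 2 but does not show how far the exchange itself moved the reading on this core.

As far as these compounds go, the true readings of compound 1, compound 3 and compound 4 remain open, and so does the reach of the pattern beyond these compounds. A longer chain, or a urea or an amine on that nitrogen, might give a number inside the range of the assay, but the compounds shown cannot tell.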